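The compounds below may be only part of what the source reports. "The series", "measured", "known", "first", "only" and "open" are said of these compounds alone.

In a functional assay on RAW264.7 cells (Mus musculus) for inhibition, read by Griess assay, with a stated time of 20 h (a lower number here means a stronger inhibitor, a higher number a weaker inhibitor), compound 1 (`CCCNC(=O)c1ccc(-n2cc(-c3ccccc3)nn2)cc1O`) gives > 20000 nM, which is a limit of the assay and not a number. Compound 2 (`CCCCCCc1cn(-c2ccc(C(=O)NCCC)c(O)c2)nn1`), with hexyl in place of phenyl on an aromatic carbon, gives > 20000 nM, again a limit. Compound 3 (`CCCNC(=O)c1ccc(-n2cc(-c3cccc(Cl)c3)nn2)cc1O`), with chloro in place of hydrogen on an aromatic carbon, gives > 20000 nM, also a limit. Compound 1 therefore offers no number from which to count, and the two other values beside it offer none either.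

Compound 4 (`O=C(c1ccc(-n2cc(-c3ccccc3)nn2)cc1O)N1CCCCC1`) keeps the core of compound 1 and alters one place: piperidin-1-yl in place of propylamino on a carbonyl carbon. In words, piperidin-1-yl stands in place of propylamino on a carbonyl carbon. The measured steps give little guidance, since they are a step that the two limits leave unreadable from compound 1 to compound 2 and a step that the two limits leave unreadable from compound 1 to compound 3, and neither changes the group on the carbonyl carbon. What remains is the limit of > 20000 nM in this assay, at which 3 of the 3 values shown sit. No size or direction of step can be drawn from these compounds, so compound 4 is expected to stay near that limit, and the assay may well report only a limit again. The expected change is a step that the limit leaves unreadable from compound 1 to compound 4. For compound 4 the estimated value is 30000 nM, with an expected range from 8000 nM to 60000 nM.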

Compound 4, half-maximal inhibitory concentration: > 20000 nM
Compound 4: a limit, no number; the forecaster's own chance of this, stated with the estimate: 80%; the middle value is on the limit's open side.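

In this assay compound 4 gives > 20000 nM, which is a limit and not a number. Compound 1 also stands only at a limit, so no step can be read between compound 1 and compound 4. The compounds shown leave open whether any change among them alters the inhibition, and by how much: the limit of > 20000 nM in this assay, at which 4 of the 4 values shown sit.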